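The source may hold more compounds than are shown below. What is called first, only, known or untested is meant among the compounds shown, and "the series" means these compounds.

Working notes on the series in an ADME assay on microsomes from liver (Mus musculus, strain CD1) for metabolic stability, read by LC-MS, using NADPH, with a stated time of 60 min; a higher number here means that the compound lasts longer, a lower number that the compound disappears faster.

Of the compounds shown here, three have numbers so far. Compound 1 `COc1ccc(-c2c(-c3ccc(OC)cc3)n(Cc3ccccc3)c3ncn([C@@H]4CCCC[C@H]4O)c(=N)c23)cc1` gives 0.487 h in this assay. Compound 3 `COc1ccc(Cn2c(-c3ccccc3)c(-c3ccccc3)c3c(=N)n(CC4CCOCC4)cnc32)cc1` gives 0.217 h in this assay. Compound 2 `N=c1c2c(-c3ccccc3)cn(Cc3ccccc3)c2ncn1C1CCOCC1` gives 0.0867 h in this assay. Compound 1 stands highest of the three, and its gaps to compound 3 and to compound 2 both lie beyond the usual scatter of repeated runs. No two of these compounds differ in only one place, so no single structural step can be tied to a measured change.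

Compound 4 `COc1ccc(-c2c(-c3ccc(OC)cc3)n(Cc3ccccc3)c3ncn(CCCO)c(=N)c23)cc1` has not yet been measured. It departs from compound 1 as follows: 3-hydroxypropyl in place of 2-hydroxycyclohexyl on an aromatic nitrogen. The rest of the structure, including the core of compound 1, is unchanged.

Among the measured compounds shown here, with no measured step of the same kind to lean on, the expected step from compound 1 to compound 4, a 1.4-fold lower number from compound 1 to compound 4 (0.14 log units; within the scatter), is estimated as small and not clearly beyond the scatter, if anything downward. The half-life of compound 4 is estimated at 0.35 h, within a range from 0.15 h to 0.8 h.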

Compound 4, half-life: 0.36 h
Beside the measured number, compound 4's estimate is 1.0-fold (0.01 log units) below it, and the stated range covers the measured number.
By their numbers in this assay, from the lowest: compound 2; then compounds 3, 4 and 1 (each within the scatter of the next, the first and the last beyond it).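

In this assay, among the compounds shown here, the step at this position, on an aromatic nitrogen, is the first that can be read for a single change: 3-hydroxypropyl in place of 2-hydroxycyclohexyl gives a 1.4-fold lower number from compound 1 to compound 4 (0.13 log units; within the scatter) and so stays within the scatter. On the core of compound 1, the six-membered carbon ring and both defined stereocentres therefore leave without a change that can be told from the scatter, while the hydrogen-bond donor and acceptor counts of the group stay the same. Nothing available explains this result.

From the compounds shown here alone, it remains open how this position responds to a group ending in an amine or a carboxylic acid, or to a plain propyl chain. Going by these compounds, whether the same step holds on other cores is also open.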